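This account rests on a few compounds, and the source may have more. Where it says the series, first, only, none or still open, it means among the compounds named here.

In a functional assay on MDA-MB-231 cells (Homo sapiens) for inhibition, read by MTT assay, with a stated time of 72 h (on this read-out lower numbers stand for stronger inhibition of growth and higher numbers for weaker inhibition of growth), compound 1 (`O=C1CC(N2C(=O)CSC2=S)C(=O)N1c1ccc(Cl)cc1`) gives > 100000 nM, a limit of the assay and not a number. Compound 2 (`O=C1CC(N2C(=O)CSC2=S)C(=O)N1c1ccc(O)cc1`) gives > 100000 nM, which is also a limit. Among the compounds with values here, the only number in the set belongs to compound 3 (`O=C1CC(N2C(=O)/C(=C/C(Cl)=C/c3ccc([N+](=O)[O-])cc3)SC2=S)C(=O)N1c1ccc(Cl)cc1`), at 6450 nM, while the other two values stand at the limit of > 100000 nM in this assay, at which 2 of the 3 values shown sit.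

Compound 4 (`O=C1CC(N2C(=O)/C(=C/C(Cl)=C/c3ccc([N+](=O)[O-])cc3)SC2=S)C(=O)N1c1ccc(O)cc1`) differs from compound 3 by a single exchange, (hydroxy in place of chloro on an aromatic carbon), with hydroxy in place of chloro on an aromatic carbon, para to a large group. The same exchange has been measured only once, as a step that the two limits leave unreadable from compound 1 to compound 2. That step therefore offers neither a size nor a direction. With nothing readable to draw on, no shift beyond the usual scatter is expected in this assay, although the uncertainty is wide in both directions. The expected change is a 1.1-fold higher number from compound 3 to compound 4 (0.04 log units; within the scatter). Compound 4 is estimated at 7000 nM, with an expected range of 2500 nM to 25000 nM.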

Compound 4, concentration for 50% growth inhibition: 6200 nM
For compound 4 the middle estimate is 1.1-fold (0.05 log units) above the measured one; measured number inside the range.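

In this assay, within the data shown here, the exchange of chloro for hydroxy on an aromatic carbon, para to a large group, now has a readable size for the first time: a 1.0-fold lower number from compound 3 to compound 4 (0.02 log units; within the scatter). For this one pair, the 4-chlorophenyl and 4-hydroxyphenyl forms are therefore not told apart by this read-out. The earlier step from compound 1 to compound 2 could not show this, because both of its values are limits and not numbers: the limit of > 100000 nM in this assay, at which 2 of the 4 values shown sit.

Among the compounds shown, only chloro and hydroxy stand at this position, so it remains open how an amine, a methoxy group or a carboxylic acid there would read. On these data alone, it also remains open whether the exchange would read the same on the core of compound 1 if a number could be obtained there.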